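A few compounds are considered here, and "the series" means these few. Any claim that something is new, unique, unknown or untested is made for them only; others in the source may bear on it.

Measured so far:
compound 1 `CN(C(=O)c1ccc(Cl)cc1)c1ccc2[nH]c(-c3n[nH]c4ccccc34)cc2n1` — 630 nM
compound 2 `COc1ccc(S(=O)(=O)N(C)c2ccc3[nH]c(-c4n[nH]c5ccccc45)cc3n2)cc1` — 22100 nM

In a functional assay on KB cells (Homo sapiens) for antiproliferative activity, read by MTT assay, with a stated time of 72 h (a higher number here means a weaker inhibitor, a lower number a stronger inhibitor), compound 1 gives the lower of the two numbers, and compound 2 sits well beyond the scatter above it. Within the data shown here, no single-point step between the two measured compounds is available; they differ in more than one place.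

Compound 3 `CN(C(=O)Nc1ccccc1)c1ccc2[nH]c(-c3n[nH]c4ccccc34)cc2n1` is the next analogue of compound 1. The change is anilino in place of 4-chlorophenyl on a carbonyl carbon — anilino in place of 4-chlorophenyl on a carbonyl carbon, giving phenylcarbamoyl where (4-chlorophenyl)carbonyl stood. Among the measured compounds shown here, no comparable step in this assay is known, so the expected step of a 2.4-fold higher number from compound 1 to compound 3 (0.38 log units; beyond the scatter) is a modest loss, close to the edge of the scatter. Compound 3 is estimated at 1500 nM in this assay, with a range from 400 nM to 6000 nM.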

Compound 3, half-maximal inhibitory concentration: 32 nM
Beside the measured number, compound 3's estimate is 47-fold (1.67 log units) above it; the whole stated range lies above it.
By their numbers in this assay, from the lowest: compound 3; then compound 1; then compound 2.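

On the carbonyl carbon whose other neighbour is the amide-type nitrogen, anilino in place of 4-chlorophenyl gives a 20-fold lower number from compound 1 to compound 3 (1.29 log units; beyond the scatter) in this assay. Among these compounds, this is the first single-place reading, and it shows that the group on this carbonyl carbon can move the number by a large step. No measured evidence on the cause of this step is at hand.

The change swaps in the anilino nitrogen and removes the chlorine together, and the two remain unseparated. A 4-chloroanilino group or a phenoxy group on the same carbonyl carbon would pull them apart.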